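Demethylation of the methoxy group in a pyrazole series

A few compounds are considered here, and "the series" means these few. Any claim that something is new, unique, unknown or untested is made for them only; others in the source may bear on it.

Measured so far:
- compound 1 `Cc1cc(O)cc(-c2nn(CC#N)cc2-c2ccnc(-c3ccc(Oc4ccccc4)cc3)c2)c1`: 1740 nM
- compound 2 `COc1cc(C)cc(-c2nn(CC#N)cc2-c2ccnc(-c3ccc(N(C)C)cc3)c2)c1`: 402 nM

Both compounds were tested in a functional assay on IGROV-1 cells (Homo sapiens) for inhibition, read by sulforhodamine B assay, with a stated time of 48 h; on this read-out higher numbers stand for weaker inhibition of growth and lower numbers for stronger inhibition of growth. Compound 2 gives the lower of the two numbers, 402 nM, and compound 1, beyond the scatter from it, gives 1740 nM. The two differ in more than one place, so no single change can be read from that gap.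

Compound 3 `Cc1cc(O)cc(-c2nn(CC#N)cc2-c2ccnc(-c3ccc(N(C)C)cc3)c2)c1` has not been measured. It is derived from compound 2 by one change: hydrogen in place of methyl on an oxygen on an aromatic ring. The change sits on an oxygen on an aromatic ring whose other neighbours are aromatic carbon; cut one bond further out it reads methoxy to hydroxy, or 3-methoxy-5-methylphenyl to 3-hydroxy-5-methylphenyl. Within the data shown here, no measured pair in the set shows this change on its own, so its size and direction are not known from the data. Compound 1 already carries the hydroxy group together with a different substituent on the other ring, which does not isolate the effect.

The step from compound 2 to compound 3 is expected to be small, a 1.3-fold lower number from compound 2 to compound 3 (0.10 log units; within the scatter), within the scatter. For compound 3 the estimate in this assay is 320 nM, with a range of 100 nM to 1000 nM.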

Compound 3, concentration for 50% growth inhibition: 3910 nM
Estimate against measurement, compound 3: 12-fold (1.09 log units) below; measured number outside the range, above it.
By their numbers in this assay, from the lowest: compound 2; then compound 1; then compound 3.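

In this assay, the replacement of methoxy by hydroxy on the 3-methoxy-5-methylphenyl group can now be read on its own, with dimethylamino held constant on the other ring, and it weakens growth inhibition: the step is a 9.7-fold higher number from compound 2 to compound 3 (0.99 log units; beyond the scatter), beyond the scatter, so the methyl on this oxygen cannot be treated as a silent feature in this pair. With the hydroxy group held constant, dimethylamino in place of phenoxy on an aromatic carbon gives a 2.2-fold higher number from compound 1 to compound 3 (0.35 log units; beyond the scatter), also beyond the scatter, which shows that the substituent on the other ring matters too, although by a smaller step in this single pair. No supporting data bear on why either step takes the size it does.

On these data alone, each change is read against one background only, so it remains open whether the step at this oxygen keeps its size and direction with phenoxy on the other ring. Also open, as far as these compounds go, is how a longer chain on this oxygen, such as ethyl or propyl, or a difluoromethyl group there, would read against methyl and hydrogen.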